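The compounds below may be only part of what the source reports. "The series", "measured", "known", "first", "only" and "open" are said of these compounds alone.

Measured in an ADME assay on Vero cells (Chlorocebus sabaeus) for cytotoxicity; on this read-out higher numbers stand for lower toxicity in this test and lower numbers for higher toxicity in this test:
- compound 1 `CCCCCC(=O)Nc1nc(N)nc2c1ncn2[C@H]1CO[C@@H](CO)O1`: > 100000 nM
- compound 2 `CCCCCCCCCCCCCCCC(=O)Nc1nc(N)nc2c1ncn2[C@H]1CO[C@@H](CO)O1`: 90000 nM

In this assay compound 1 gives > 100000 nM, which is a limit of the assay and not a number. Compound 3 `CCCCCCCC/C=C\CCCCCCCC(=O)Nc1nc(N)nc2c1ncn2[C@H]1CO[C@@H](CO)O1` differs from compound 1 by dodec-3-en-1-yl in place of hydrogen on a saturated chain carbon, five bonds along the chain from a carbonyl carbon. For the measured compounds named here, the one measured step that bears on this change, decyl in place of hydrogen on that same saturated chain carbon, is an at least 1.1-fold lower number from compound 1 to compound 2 (0.04 log units; that floor lies within the scatter), and it lies within the scatter. A longer chain at this place is therefore expected to bring no change beyond the scatter. The expected step is an at least 1.1-fold lower number from compound 1 to compound 3 (0.04 log units; that floor lies within the scatter). For compound 3 the estimated value is 90000 nM, with an expected range from 45000 nM to 180000 nM.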

Compound 3, half-maximal cytotoxic concentration: 19000 nM
Compound 3: the middle estimate sits 4.7-fold (0.68 log units) above what was measured, and the stated range ends above it.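

In this assay, dodec-3-en-1-yl at this place gives an at least 5.2-fold lower number from compound 1 to compound 3 (0.72 log units; beyond the scatter), so a change at this chain carbon can move the read-out towards higher toxicity in this test, which decyl did not show. Dec-1-en-1-yl in place of octyl gives a 4.7-fold lower number from compound 2 to compound 3 (0.68 log units; beyond the scatter). The first of these steps is only a floor, because compound 1 stands at a limit and not a number: the limit of > 100000 nM in this assay, at which 1 of the 3 values shown sits.

Dec-1-en-1-yl adds chain length and a double bond at once, and the compounds shown do not separate the two. On these data alone, a saturated chain as long as that of compound 3, or a still longer chain, remains open.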